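The source may report more compounds than this note shows. Statements on the series, on what has been measured and on what is new or still open speak of the compounds shown alone.

Measured compounds:
compound 1 `CC(C)(Oc1ccccc1)C1OCC(C/C=C\CCC(=O)O)C(c2cccnc2)O1` — 52 nM
compound 2 `CSc1ccc(OC(C)(C)C2OCC(C/C=C\CCC(=O)O)C(c3cccnc3)O2)c([N+](=O)[O-])c1` — 22 nM
compound 3 `Cc1ccc(OC(C)(C)C2OCC(C/C=C\CCC(=O)O)C(c3cccnc3)O2)cc1` — 360 nM

In an assay for inhibition of Thromboxane-A synthase (Homo sapiens), using microsomes (a higher number here means a weaker inhibitor, a lower number a stronger inhibitor), compound 3 stands at the weak end of the three: one step that reaches it is a 6.9-fold higher number from compound 1 to compound 3 (0.84 log units; beyond the scatter), and the other is a 16-fold higher number from compound 2 to compound 3 (1.21 log units; beyond the scatter), both beyond the scatter. Compound 4 `COc1ccccc1OC(C)(C)C1OCC(C/C=C\CCC(=O)O)C(c2cccnc2)O1` is not yet measured. It differs from compound 3 by 2-methoxyphenyl in place of 4-methylphenyl on an oxygen on a saturated carbon.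

Within the data shown here, two measured steps bear on this change. The step from compound 1 to compound 3, a 6.9-fold higher number from compound 1 to compound 3 (0.84 log units; beyond the scatter), shows that removing the methyl from the aryl group would be expected to return the number roughly to that of compound 1. The step from compound 2 to compound 3, a 16-fold higher number from compound 2 to compound 3 (1.21 log units; beyond the scatter), shows that a differently substituted aryl group on the same oxygen can give a much lower number still. Among the measured compounds shown here, the methoxy group in compound 4 is new to this set, so no measured step tells its own effect directly.

On balance, compound 4 is expected to show a step of a 6.0-fold lower number from compound 3 to compound 4 (0.78 log units; beyond the scatter) in this assay, a lower number than compound 3, landing near compound 1. The estimate for compound 4 in this assay is 60 nM, with a range from 20 nM to 200 nM.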

Compound 4, half-maximal inhibitory concentration: 60 nM
Estimate against measurement, compound 4: no gap at the digits printed, within the range that was stated.
By their numbers in this assay, from the lowest: compound 2; then compounds 1 and 4 (each within the scatter of the next); then compound 3.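

In this assay, replacing 4-methylphenyl with 2-methoxyphenyl on this oxygen recovers most of the ground lost in compound 3, a 6.0-fold lower number from compound 3 to compound 4 (0.78 log units; beyond the scatter), so a substituted aryl group here need not carry a penalty of that size. Compound 4 cannot be told apart from the unsubstituted parent, a 1.2-fold higher number from compound 1 to compound 4 (0.06 log units; within the scatter), yet it does not reach the more heavily substituted aryl group of compound 2, a 2.7-fold higher number from compound 2 to compound 4 (0.44 log units; beyond the scatter). No supporting data accompany these results to account for these differences.

Because 4-methylphenyl and 2-methoxyphenyl differ both in the substituent and in where it sits on the aryl group, the compounds shown do not separate those two changes. Going by these compounds, how an aryl group bearing an amine or a carboxylic acid would behave at this position also remains open.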